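Methylating the ring nitrogen of compound 1: working notes

A few compounds are considered here, and "the series" means these few. Any claim that something is new, unique, unknown or untested is made for them only; others in the source may bear on it.

- compound 1 `CCOC(=O)/C=C/c1ccncc1-c1ccc2[nH]ccc2c1`: > 10000 nM (a limit)
- compound 2 `O=C(O)/C=C/c1ccncc1-c1ccc2ccccc2c1`: > 10000 nM (a limit)
- compound 3 `Cn1ncc2cc(-c3cnccc3/C=C/C(=O)O)ccc21`: > 10000 nM (a limit)

All three compounds were tested in a functional assay on MCF7 cells (Homo sapiens) for inhibition, read by sulforhodamine B assay, with a stated time of 72 h (on this read-out lower numbers stand for stronger inhibition of growth and higher numbers for weaker inhibition of growth), and none of them gives a number. Compound 1 stands at a limit of the assay, and so do the two others, as the limit of > 10000 nM in this assay, at which 3 of the 3 values shown sit, records. No order among the three can be read from these results.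

Compound 4 `CCOC(=O)/C=C/c1ccncc1-c1ccc2c(ccn2C)c1`, not yet measured, keeps the core of compound 1 and differs by methyl in place of hydrogen on an aromatic nitrogen. Among the compounds with values here, no measured pair shows this change or any other single change. No step beyond the usual scatter is expected in this assay. This expectation rests only on compound 1, whose value of > 10000 nM is a limit. The expected step that the limit leaves unreadable from compound 1 to compound 4 is therefore small, and a further limit is the likeliest result. For compound 4 the estimate is 12000 nM, with an expected range from 4000 nM to 30000 nM.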

Compound 4, concentration for 50% growth inhibition: 8670 nM
Compound 4: middle estimate off by 1.4-fold (0.14 log units), on the high side; low and high end bracket the measured number.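

In this assay, within the data shown here, compound 4 gives 8670 nM, the first number rather than a limit. Methyl in place of hydrogen on an aromatic nitrogen therefore brings an at least 1.1-fold lower number from compound 1 to compound 4 (0.06 log units; that floor lies within the scatter), so this position tolerates the change and the change can move the read-out to a measurable value, though the step is only a floor. Its true size stays unreadable, since the value for compound 1 is a limit, as are those of two of the other compounds: the limit of > 10000 nM in this assay, at which 3 of the 4 values shown sit.

As far as these compounds go, whether the step from hydrogen to methyl really exceeds the usual scatter remains open. Also open, from the compounds shown here alone, is how an ethyl group, or a longer chain ending in an amine, on the same aromatic nitrogen would read against compound 4.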